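Benzyl for tert-butyl at the chain end of compound 3

A few compounds are considered here, and "the series" means these few. Any claim that something is new, unique, unknown or untested is made for them only; others in the source may bear on it.

Measured compounds and their values:
Compound 1 `COc1ccc(-c2cc(NC(=O)CCC(=O)NCC(=O)NC3CCCCC3)nc(-c3ccc(OC)cc3)n2)cc1`: 74200 nM
Compound 2 `COc1ccc(-c2cc(NC(=O)CCC(=O)N(C)CC(=O)NCc3ccccc3)nc(-c3ccc(OC)cc3)n2)cc1`: 35400 nM
Compound 3 `COc1ccc(-c2cc(NC(=O)COCC(=O)NCC(=O)NC(C)(C)C)nc(-c3ccc(OC)cc3)n2)cc1`: 19700 nM

In an assay on HeLa cells for displacement of a labelled ligand from adenosine receptor A3 (Homo sapiens), read by fluorescence polarization, with a stated time of 30 min (on this read-out higher numbers stand for weaker inhibition and lower numbers for stronger inhibition), compound 3 gives 19700 nM, the lowest of the three numbers. Compound 2 gives 35400 nM, which lies within the scatter of compound 3, so the two cannot be told apart. Compound 1 gives 74200 nM, a number beyond the scatter from compound 3.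

Compound 4 `COc1ccc(-c2cc(NC(=O)COCC(=O)NCC(=O)NCc3ccccc3)nc(-c3ccc(OC)cc3)n2)cc1` keeps the shared core and the chain of compound 3 and alters only its end: benzyl in place of tert-butyl on an amide-type nitrogen. Within the data shown here, no pair among the measured compounds differs in this one place alone, so no measured step tells how large such an exchange is. Compound 2, which also carries a benzyl on its terminal amide nitrogen, sits close to compound 3, which hints that the exchange need not move the number far. The step from compound 3 to compound 4 is therefore expected to be small, a 1.1-fold higher number from compound 3 to compound 4 (0.05 log units; within the scatter), and not clearly beyond the scatter. Compound 4 is estimated at 22000 nM, with a range from 7000 nM to 65000 nM.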

Compound 4, inhibition constant: 185000 nM
Estimate against measurement, compound 4: 8.4-fold (0.92 log units) below; the whole stated range lies below it.
By their numbers in this assay, from the lowest: compounds 3 and 2 (each within the scatter of the next); then compound 1; then compound 4.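

In this assay, among these compounds, the exchange of tert-butyl for benzyl on an amide-type nitrogen gives a 9.4-fold higher number from compound 3 to compound 4 (0.97 log units; beyond the scatter) and is the first single change here whose size can be read. This position at the end of the chain is therefore not indifferent to what it carries: the entering group brings more heavy atoms and a six-membered aromatic ring of carbon only, and inhibition is weaker with it, though a single pair cannot show which of these features counts. No measurement available here bears on the reason for this step.

Still open, as far as these compounds go, is how the position responds to other groups, such as a 2-phenylethyl group, a carboxylic acid or an amine at the chain end. From the compounds shown here alone, it is also open whether the same exchange would give a step of similar size on the chains of compound 1 and compound 2.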